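The source may hold more compounds than are shown below. What is called first, only, known or untested is meant among the compounds shown, and "the series" means these compounds.

Of the compounds shown here, two have been measured so far. Compound 1 `COc1ncc(-c2ccc3ncc(C(=O)N4CCC(O)CC4)n3c2)cc1NS(=O)(=O)c1ccc(F)cc1F` gives 790 nM in a functional assay on SK-HEP1 cells (Homo sapiens) for antiproliferative activity, read by sulforhodamine B assay, with a stated time of 72 h (on this read-out lower numbers stand for stronger inhibition and higher numbers for weaker inhibition), the higher of the two numbers. Compound 2 `CCOC(=O)c1cc2cc(-c3cnc(OC)c(NS(=O)(=O)c4ccc(F)cc4)c3)ccc2[nH]1` gives 300 nM in the same assay, a difference beyond the scatter. Compound 3 `CCOC(=O)c1cnc2ccc(-c3cnc(OC)c(NS(=O)(=O)c4ccc(F)cc4F)c3)cn12` has not yet been measured. It differs from compound 1 in one place: ethoxy in place of 4-hydroxypiperidin-1-yl on a carbonyl carbon. Compound 2 also carries ethoxycarbonyl, on a different core, and its number is lower than that of compound 1. From compound 1 a moderate downward step a 2.0-fold lower number from compound 1 to compound 3 (0.30 log units; within the scatter) is therefore expected. Compound 3 is estimated at 400 nM, within a range from 150 nM to 1200 nM.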

Compound 3, half-maximal inhibitory concentration: 300 nM
For compound 3 the middle estimate is 1.3-fold (0.12 log units) above the measured one; measured number inside the range.
By their numbers in this assay, from the lowest: compounds 2 and 3 (each within the scatter of the next); then compound 1.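

In this assay, ethoxy in place of 4-hydroxypiperidin-1-yl on a carbonyl carbon gives a 2.6-fold lower number from compound 1 to compound 3 (0.42 log units; beyond the scatter) on an unchanged core. The ring and its hydrogen-bond donor are therefore not needed for activity at this position, and the smaller group gives the lower number. No measurement shown here accounts for this step.

As far as these compounds go, it remains open whether the gain follows from losing the ring or only its hydroxyl, which an amide of plain piperidine could separate. How a carboxylic acid or a longer chain would read at this carbonyl carbon is also unknown.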